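Swapping the ester aryl group for a hydroxybenzyl group

A few compounds are considered here, and "the series" means these few. Any claim that something is new, unique, unknown or untested is made for them only; others in the source may bear on it.

Measured compounds:
Compound 1 `COc1ccc(C(=O)OC2(C(=O)Nc3ccc([N+](=O)[O-])cc3)CCCCC2)cc1` gives 57.1 nM in a functional assay on HepG2 cells (Homo sapiens) for inhibition, read by MTT assay, with a stated time of 72 h; a higher number here means a weaker inhibitor, a lower number a stronger inhibitor.
Compound 2 `CCC(=O)OC1(C(=O)Nc2ccc([N+](=O)[O-])cc2)CCCCC1` gives 21.5 nM in this assay.

Among the compounds with values here, on these two numbers compound 1 stands highest; the only step, a 2.7-fold lower number from compound 1 to compound 2 (0.42 log units; beyond the scatter), replaces the aryl on the ester carbonyl with a small chain. Compound 3 `O=C(OC1(C(=O)Nc2ccc([N+](=O)[O-])cc2)CCCCC1)C(O)c1ccccc1` differs from compound 1 by hydroxy(phenyl)methyl in place of 4-methoxyphenyl on a carbonyl carbon. That step bears only loosely on it, since the entering group is neither aryl nor plain chain, so a small lowering or none beyond the scatter is expected, a 1.4-fold lower number from compound 1 to compound 3 (0.15 log units; within the scatter). Compound 3 is therefore estimated at 40 nM, between 15 nM and 150 nM.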

Compound 3, half-maximal inhibitory concentration: 7.7 nM
For compound 3 the middle estimate is 5.2-fold (0.72 log units) above the measured one, outside the stated range (below it).
By their numbers in this assay, from the lowest: compound 3; then compound 2; then compound 1.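

Hydroxy(phenyl)methyl on this carbonyl carbon gives a 7.4-fold lower number from compound 1 to compound 3 (0.87 log units; beyond the scatter) and also a 2.8-fold lower number from compound 2 to compound 3 (0.45 log units; beyond the scatter). This places compound 3 lowest of the three, ahead of both the 4-methoxyphenyl and the ethyl compounds. Compounds 1 and 3 hold the same atoms, joined differently, and each group carries one aromatic ring, so this position responds to arrangement and not just to atom content, though no evidence here explains why.

The compounds shown leave open whether the hydroxy group itself matters. A plain benzyl group or an aminomethyl group on this carbonyl carbon would test that.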